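This account rests on a few compounds, and the source may have more. Where it says the series, first, only, none or still open, it means among the compounds named here.

Measured compounds:
- compound 1 `COc1ccc(OC)c(N2C(=O)CSC2c2cccc(C(=O)NCCCCc3ccccc3)c2)c1` gives 5% in a functional assay on HOS cells (Homo sapiens) for inhibition, read by CCK-8 assay, with a stated time of 72 h, tested at 1 uM; a lower number here means less inhibition, a higher number more inhibition at the concentration tested (going by the name of the read-out)
- compound 2 `CCN1C(=O)CSC1c1cccc(C(=O)NCCCCc2ccccc2)c1` gives 6%
- compound 3 `O=C(NCCCCc1ccccc1)c1cccc(C2SCC(=O)N2c2cccc(F)c2)c1` gives 84%

Compound 3 stands highest of the three numbers. Its nearest neighbour is compound 2, a number 78 percentage points higher from compound 2 to compound 3 (beyond the scatter); its furthest is compound 1, a number 79 percentage points higher from compound 1 to compound 3 (beyond the scatter). Compound 1 and compound 2 sit within the scatter of each other, a number 1 percentage points higher from compound 1 to compound 2 (within the scatter).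

Compound 4 `COc1ccc(N2C(=O)CSC2c2cccc(C(=O)NCCCCc3ccccc3)c2)c(OC)c1` is not yet measured. It differs from compound 3 at one place: 2,4-dimethoxyphenyl in place of 3-fluorophenyl on an amide-type nitrogen in a ring

Going by the values given here, the step that bears on this change most directly is the one from compound 1 to compound 3, where a dimethoxyphenyl group on the same ring nitrogen was replaced by 3-fluorophenyl and inhibition rose sharply, a number 79 percentage points higher from compound 1 to compound 3 (beyond the scatter). Compound 4 reverses that direction, bringing back a dimethoxyphenyl group, now 2,4-dimethoxyphenyl rather than 2,5-dimethoxyphenyl. Among the compounds with values here, no measured step covers the two dimethoxyphenyl isomers against each other, so their equivalence is not known. On the evidence of compound 1 giving 5%, a large drop is expected, a number 64 percentage points lower from compound 3 to compound 4 (beyond the scatter), with the upper end left wide for the untested isomer. The estimate for compound 4 is 20%, between 0% and 60%.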

Compound 4, a percentage reported as inhibition, at one concentration (the size of the read-out at that concentration, not a potency): 82%
Beside the measured number, compound 4's estimate is 62 percentage points below it; measured number above the stated range.
By their numbers in this assay, from the lowest: compounds 1 and 2 (each within the scatter of the next); then compounds 4 and 3 (each within the scatter of the next).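

In this assay the step of a number 2 percentage points lower from compound 3 to compound 4 (within the scatter) shows that 2,4-dimethoxyphenyl on the amide-type nitrogen in the ring cannot be told apart from 3-fluorophenyl, so this position accepts a substituted phenyl carrying either fluorine or two methoxy groups. The step of a number 76 percentage points higher from compound 2 to compound 4 (beyond the scatter) puts 2,4-dimethoxyphenyl well clear of ethyl, while the step of a number 77 percentage points higher from compound 1 to compound 4 (beyond the scatter) is a change of isomer alone, so a dimethoxyphenyl group as such does not set the low number, and the arrangement of its two methoxy groups on the phenyl ring separates the two isomers in this series. No measurement at hand gives a reason for this large gap between the isomers.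

The compounds shown leave open which methoxy group carries the difference, a question that 2-methoxyphenyl, 4-methoxyphenyl and 3-methoxyphenyl on the same nitrogen would address. They also leave open how far this position extends beyond substituted phenyl, for example to a pyridine ring or a benzyl group, and whether the pair at the top of the range would stay together at other concentrations.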